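This account rests on a few compounds, and the source may have more. Where it says the series, first, only, none or still open, it means among the compounds named here.

Of the compounds shown here, three built on one shared core have been tested in a functional assay on MCF7 cells (Homo sapiens) for cytotoxicity, read by CCK-8 assay, with a stated time of 72 h; a lower number here means a stronger inhibitor, a higher number a weaker inhibitor. Compound 1 `C=CCn1c(=O)/c(=C\c2ccccc2Cl)[nH]c(=O)/c1=C\c1ccccc1OC` gives 4700 nM. Compound 2 `C=CCn1c(=O)/c(=C\c2ccccc2OC)[nH]c(=O)/c1=C\c1ccccc1OC` gives 41100 nM, and compound 3 `C=CCn1c(=O)/c(=C\c2cccc(Br)c2)[nH]c(=O)/c1=C\c1ccccc1OC` gives 5400 nM. Among these three numbers compound 3 holds the second highest place: its nearest neighbour is compound 1, where a 1.1-fold higher number from compound 1 to compound 3 (0.06 log units; within the scatter), and its furthest is compound 2, where a 7.6-fold lower number from compound 2 to compound 3 (0.88 log units; beyond the scatter).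

Compound 4 `C=CCn1c(=O)/c(=C\c2cccc(Br)c2)[nH]c(=O)/c1=C\c1cccc(Br)c1` has not yet been measured. It differs from compound 3 in one place: 3-bromophenyl in place of 2-methoxyphenyl on a double-bonded chain carbon bound to an aromatic carbon. Two of the measured steps speak to this exchange. The very same exchange has already been made once within this small set, in the step from compound 2 to compound 3, where a 7.6-fold lower number from compound 2 to compound 3 (0.88 log units; beyond the scatter). A closely related exchange, methoxy in place of chloro, runs the other way in the step from compound 1 to compound 2, where an 8.7-fold higher number from compound 1 to compound 2 (0.94 log units; beyond the scatter). Both steps point in the same direction, so a lower number, beyond the scatter, is expected for compound 4 in this assay. Compound 4 is therefore estimated at 900 nM, with a likely range from 300 nM to 3500 nM, which amounts to an expected 6.0-fold lower number from compound 3 to compound 4 (0.78 log units; beyond the scatter).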

Compound 4, half-maximal inhibitory concentration: "not active" (no number reported)
For compound 4 the study gives words and no number; the estimate stays without a comparison.
By their numbers in this assay, from the lowest: compounds 1 and 3 (each within the scatter of the next); then compound 2.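

In this assay, going by these compounds alone, compound 4 is reported only in words, as "not active", without a number, so no step from compound 3 to compound 4 can be read. Nothing shown here offers an explanation for this result. These compounds leave open how 3-bromophenyl in place of 2-methoxyphenyl at this second place changes the number, and by how much.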